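A few compounds are considered here, and "the series" means these few. Any claim that something is new, unique, unknown or untested is made for them only; others in the source may bear on it.

Compound 1 `Cc1ccc(NC(=O)N[C@@H](C)c2ccccc2)cc1`: 100%
Compound 2 `CCCCCCCc1ccc(NC(=O)N[C@@H](C)c2ccccc2)cc1`: 99%
Compound 3 `CCOC(=O)c1ccc(NC(=O)N[C@@H](C)c2ccccc2)cc1`: 92%

In an ADME assay on the whole organism with Oryza sativa as the target, tested at 10 uM (on this read-out higher numbers stand for a weaker effect at the one concentration tested and lower numbers for a stronger effect), compound 3 sits at the bottom of the three numbers, yet the steps of a number 8 percentage points lower from compound 1 to compound 3 (within the scatter) and a number 7 percentage points lower from compound 2 to compound 3 (within the scatter) both lie within the scatter, so the three compounds cannot be told apart on these data. Compound 4 `C[C@H](NC(=O)Nc1ccc(I)cc1)c1ccccc1` differs from compound 3 by iodo in place of ethoxycarbonyl on an aromatic carbon. Among the compounds with values here, the steps that bear on this change are the two ending at compound 3, which likewise swap a group on an aromatic carbon, and neither moved the read-out beyond the scatter. Hence no step beyond the scatter is expected in this assay for compound 4, a number 5 percentage points higher from compound 3 to compound 4 (within the scatter). Compound 4 is estimated to give 97%, with a range from 85% to 100%.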

Compound 4, a percentage reported as activity, at one concentration (the size of the read-out at that concentration, not a potency): 95%
Estimate against measurement, compound 4: 2 percentage points above; the range from low to high includes it.
By their numbers in this assay, from the lowest: compounds 3, 4, 2 and 1 (each within the scatter of the next).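

Within the data shown here, with a number 3 percentage points higher from compound 3 to compound 4 (within the scatter) and a number 4 percentage points lower from compound 2 to compound 4 (within the scatter) and also a number 5 percentage points lower from compound 1 to compound 4 (within the scatter) all inside the scatter, swapping in iodo, a single heavy atom with no hydrogen-bond acceptors, gives no step that can be read in this assay. A halogen at this place, para to a large group, therefore joins the alkyl chains and the ethoxycarbonyl group as indistinguishable on these data. Nothing available explains these numbers. On these data alone, whether an amine or a carboxylic acid at this place would give a step beyond the scatter remains open.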